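The source may hold more compounds than are shown below. What is called first, only, known or untested is meant among the compounds shown, and "the series" means these compounds.

Compound 1 `COc1ccc(Cc2cnc(CCc3ccc(-c4ccccc4C(=O)O)cc3)[nH]2)cc1` gives 513 nM in an in vitro functional assay on cells for agonist activity at Bombesin receptor subtype-3 (Mus musculus), read by luminescence and calcium flux; on this read-out higher numbers stand for an effect only at larger amounts of compound and lower numbers for an effect already at smaller amounts. Compound 2 `O=C(O)c1ccccc1-c1ccc(CCc2ncc(Cc3ccccc3F)[nH]2)cc1` gives 9.5 nM. Compound 3 `CCCCc1cnc(CCc2ccc(-c3ccccc3C(=O)O)cc2)[nH]1` gives 93 nM.

Compound 3 stands second highest of the three numbers; its nearest neighbour is compound 1, at a higher number, and its furthest is compound 2, at a lower one. Compound 4 `O=C(O)c1ccccc1-c1ccc(CCc2ncc(CC3CC3)[nH]2)cc1` differs from compound 3 by cyclopropyl in place of propyl on a saturated chain carbon bound to an aromatic carbon. Among the compounds with values here, none of the measured steps exchanges one saturated group for another: a 54-fold lower number from compound 1 to compound 2 (1.73 log units; beyond the scatter), a 5.5-fold lower number from compound 1 to compound 3 (0.74 log units; beyond the scatter) and a 9.8-fold higher number from compound 2 to compound 3 (0.99 log units; beyond the scatter) each involve 4-methoxyphenyl or 2-fluorophenyl at this position, and only the exchange of one phenyl-bearing group for the other moves the number greatly. Cyclopropyl for propyl is therefore expected to change little, and compound 4 is estimated at 70 nM (range 25 nM to 250 nM), an expected step of a 1.3-fold lower number from compound 3 to compound 4 (0.12 log units; within the scatter) within the scatter.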

Compound 4, half-maximal effective concentration: 72 nM
For compound 4 the middle estimate is 1.0-fold (0.01 log units) below the measured one; low and high end bracket the measured number.
By their numbers in this assay, from the lowest: compound 2; then compounds 4 and 3 (each within the scatter of the next); then compound 1.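

Cyclopropyl in place of propyl gives the first exchange of one saturated group for another at this position, and the ring leaves the number within the scatter (a 1.3-fold lower number from compound 3 to compound 4 (0.11 log units; within the scatter)). Compound 4 stays clearly apart from both phenyl-bearing compounds, in opposite directions (a 7.6-fold higher number from compound 2 to compound 4 (0.88 log units; beyond the scatter); a 7.1-fold lower number from compound 1 to compound 4 (0.85 log units; beyond the scatter)), so the two saturated groups sit together between them. No evidence on hand accounts for these steps.

Open, as far as these compounds go, is whether a longer chain or an amine at this position would stay near compound 4. Also open, from the compounds shown here alone, is whether unsubstituted phenyl would fall nearer 2-fluorophenyl or 4-methoxyphenyl.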